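The source may report more compounds than this note shows. Statements on the series, on what has been measured and on what is new or still open speak of the compounds shown alone.

Compound 1 `O=C1/C(=C/c2cccnc2)CN(S(=O)(=O)c2ccccc2)C/C1=C\c1ccccc1C(F)(F)F`: 12500 nM
Compound 2 `O=C1/C(=C/c2cccnc2)CN(S(=O)(=O)c2ccc(C(F)(F)F)cc2)C/C1=C\c1ccccc1C(F)(F)F`: 14300 nM

Both values come from an ADME assay on L02 cells (Homo sapiens) for cytotoxicity, read by MTT assay, with a stated time of 24 h; on this read-out higher numbers stand for weaker inhibition and lower numbers for stronger inhibition. For the measured compounds named here, compound 2, at 14300 nM, cannot be told apart from compound 1, the only other compound measured, as the two values lie within the usual scatter of each other.

The next compound is compound 3 `CC(=O)Nc1ccc(S(=O)(=O)N2C/C(=C\c3cccnc3)C(=O)/C(=C/c3ccccc3C(F)(F)F)C2)cc1`. It keeps the shared core and changes one group: acetamido in place of trifluoromethyl on an aromatic carbon. In words, this is acetamido in place of trifluoromethyl on an aromatic carbon, para to a large group.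

Going by the values given here, only one measured step bears on this change, and it concerns the same aromatic carbon: a 1.1-fold higher number from compound 1 to compound 2 (0.06 log units; within the scatter). That step put trifluoromethyl in place of hydrogen and stayed within the scatter. Among the compounds with values here, it is a single step, however, and no measured compound carries acetamido, so the evidence is thin. No shift beyond the scatter is therefore expected in this assay, though the range must stay wide. The expected step is a 1.1-fold lower number from compound 2 to compound 3 (0.04 log units; within the scatter). For compound 3 the estimated value is 13000 nM, with an expected range from 6000 nM to 30000 nM.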

Compound 3, half-maximal inhibitory concentration: 15300 nM
Estimate against measurement, compound 3: 1.2-fold (0.07 log units) below; the range from low to high includes it.
By their numbers in this assay, from the lowest: compounds 1, 2 and 3 (each within the scatter of the next).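

In this assay the aromatic carbon para to a large group has now carried acetamido as well as trifluoromethyl, and exchanging one for the other gives a 1.1-fold higher number from compound 2 to compound 3 (0.03 log units; within the scatter) while acetamido set against plain hydrogen gives a 1.2-fold higher number from compound 1 to compound 3 (0.09 log units; within the scatter) on the same carbon. The earlier pair tested only trifluoromethyl, whereas acetamido brings a hydrogen-bond donor, a hydrogen-bond acceptor and a double bond outside aromatic rings, and the number still stays within the scatter, so hydrogen and these two quite different groups cannot be told apart at this position. Nothing available here explains why the read-out stays so flat across these three compounds.

Going by these compounds, whether any group at this carbon can move the number beyond the scatter remains open, for example an amine, a carboxylic acid or a longer chain. The compounds shown also vary only this one carbon, so they say nothing about how changes elsewhere on the shared core would behave in this assay and give no basis for extending the flat result beyond compounds 1, 2 and 3.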